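Swapping 3-Aminophenyl for 4-Fluorophenyl on a Shared Core

A few compounds are considered here, and "the series" means these few. Any claim that something is new, unique, unknown or untested is made for them only; others in the source may bear on it.

Measured so far:
Compound 1 `Nc1cccc(-c2cn(CC(=O)Nc3nc4ccccc4s3)nn2)c1`: 1110 nM
Compound 2 `CCOc1cc(C(=O)Nc2nccs2)cc(OCC)c1OCC`: 6750 nM

In a functional assay on BMDM cells (Mus musculus, strain C57BL/6) for inhibition, with a stated time of 2 days (on this read-out higher numbers stand for weaker inhibition and lower numbers for stronger inhibition), compound 1 gives 1110 nM, the lowest of the two numbers shown. Compound 2 gives 6750 nM, and that gap lies beyond the usual scatter. Compound 3 `O=C(Cn1cc(-c2ccc(F)cc2)nn1)Nc1nc2ccccc2s1` has not been measured. It differs from compound 1 in one place: 4-fluorophenyl in place of 3-aminophenyl on an aromatic carbon. For the measured compounds named here, no measured pair isolates a change of this kind, so the expectation rests on compound 1 alone. The expected step is a modest move toward weaker inhibition, close to the edge of the scatter: a 1.6-fold higher number from compound 1 to compound 3 (0.21 log units; within the scatter). In this assay compound 3 is expected to give 1800 nM, with a likely range from 600 nM to 5500 nM.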

Compound 3, half-maximal inhibitory concentration: > 30000 nM
Compound 3 gave a limit, no number; the forecaster's own chance of this, stated with the estimate: 5%; middle value at least 16-fold (1.22 log units) away from the limit.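

In this assay, putting 4-fluorophenyl in place of 3-aminophenyl on the shared core gives an at least 27-fold higher number from compound 1 to compound 3 (1.43 log units; beyond the scatter). This position is therefore sensitive to which substituted phenyl it carries, although both groups hold a six-membered aromatic ring of carbon only. Compound 3 gives no number, only a limit of the assay: the limit of > 30000 nM in this assay, at which 1 of the 3 values shown sits.

Still open, on these data alone, is whether the amine itself matters or its place on the ring. Phenyl without a substituent, 4-aminophenyl and 3-fluorophenyl on the same core would separate these possibilities.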